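The source may report more compounds than this note shows. Statements on the series, on what has been measured and on what is new or still open speak of the compounds shown alone.

Compound 2 `Cc1ccc2oc(-c3ccc(NC(=O)CN4CCN(CCCN(C)C)CC4)c(C)c3)nc2c1` gives 19800 nM in a functional assay on MCF7 cells (Homo sapiens) for cytotoxicity, read by MTT assay, with a stated time of 24 h; on this read-out higher numbers stand for weaker inhibition and lower numbers for stronger inhibition. That is the lowest of the three numbers in hand, but compound 1 `CN(C)CCN1CCN(CC(=O)Nc2ccc(-c3nc4cc(F)ccc4o3)cc2)CC1`, with 20800 nM in this assay, sits within the scatter of it, so no order between the two can be read; compound 3 `Cc1ccc2oc(-c3ccc(NC(=O)CN4CCN(CCN(C)C)CC4)c(C)c3)nc2c1`, with 90300 nM, stands clearly higher. Going by the values given here, the only single-point step among the measured compounds, a 4.6-fold higher number from compound 2 to compound 3 (0.66 log units; beyond the scatter), concerns the chain and not the fused ring system. Compound 4 `Cc1cc(-c2nc3ccccc3o2)ccc1NC(=O)CN1CCN(CCCN(C)C)CC1` differs from compound 2 in one place: hydrogen in place of methyl on an aromatic carbon. Cut one bond further out, the change reads 5-methyl-1,3-benzoxazol-2-yl to 1,3-benzoxazol-2-yl. Among the compounds with values here, no measured step touches this position, and compounds 1 and 2 differ in more than one place, so their values alone cannot separate the fused ring from the chain. With nothing to point either way, compound 4 is expected to give a number close to that of compound 2, a step of a 1.1-fold higher number from compound 2 to compound 4 (0.05 log units; within the scatter) that is not expected to exceed the scatter. The estimate for compound 4 in this assay is 22000 nM, within 9000 nM to 50000 nM.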

Compound 4, half-maximal inhibitory concentration: 11300 nM
For compound 4 the middle estimate is 1.9-fold (0.29 log units) above the measured one, and the stated range covers the measured number.
By their numbers in this assay, from the lowest: compounds 4, 2 and 1 (each within the scatter of the next); then compound 3.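

Going by these compounds alone, the step of a 1.8-fold lower number from compound 2 to compound 4 (0.24 log units; within the scatter) in this assay is the first reading at this position, and it shows that the change from 5-methyl-1,3-benzoxazol-2-yl to 1,3-benzoxazol-2-yl stays within the scatter. Within the data shown here, the methyl on this aromatic carbon can therefore go without a readable change in this read-out, whereas the chain step a 4.6-fold higher number from compound 2 to compound 3 (0.66 log units; beyond the scatter) remains the only single-place step beyond the scatter. Nothing in hand offers an explanation for this result.

The compounds shown leave open whether a larger or different group on this carbon, such as methoxy, chlorine or an amine, would move the number beyond the scatter. They also leave open whether removing the methyl would give the same result with the chain of compound 3.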